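Acid to Methylamide Change on Two Related Cores

The source may hold more compounds than are shown below. What is called first, only, known or untested is meant among the compounds shown, and "the series" means these compounds.

Measured in a functional assay on WM 266-4 cells (Homo sapiens) for inhibition, with a stated time of 72 h; on this read-out lower numbers stand for stronger inhibition and higher numbers for weaker inhibition:
compound 1 `CC(C)[C@H]1CC[C@@]2(CO2)[C@H]2C(=O)OCC(C(=O)O)=C[C@H]12`: 509 nM
compound 2 `CC(C)[C@H]1CC[C@@](O)(CO)[C@H]2C(=O)OCC(C(=O)O)=C[C@H]12`: > 32000 nM, which is a limit of the assay rather than a number
compound 3 `CNC(=O)C1=C[C@@H]2[C@@H](C(C)C)CC[C@@]3(CO3)[C@H]2C(=O)OC1`: 5900 nM

Compound 3 differs from compound 1 by methylamino in place of hydroxy on a carbonyl carbon. That change produced a 12-fold higher number from compound 1 to compound 3 (1.06 log units; beyond the scatter). Compound 2 rests on a different core; the difference between the two cores is not broken down here. For compound 2 only a limit is known: the limit of > 32000 nM in this assay, at which 1 of the 3 values shown sits.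

Compound 4 `CNC(=O)C1=C[C@@H]2[C@@H](C(C)C)CC[C@@](O)(CO)[C@H]2C(=O)OC1` has not yet been measured. It differs from compound 2 by methylamino in place of hydroxy on a carbonyl carbon. The surroundings of the place are described in the same words as for the earlier pair, so this is the same change. The step from compound 2 to compound 4 is expected to be about a step that the limit leaves unreadable from compound 2 to compound 4, because the same change gave a 12-fold higher number from compound 1 to compound 3 (1.06 log units; beyond the scatter). Compound 2 already sits at a limit, so the assay would most likely again report only a limit. Compound 4 is therefore estimated at 100000 nM, expected to fall between 32000 nM and 400000 nM.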

Compound 4, half-maximal inhibitory concentration: > 32000 nM
Compound 4: a limit, no number; the forecaster's own chance of this, stated with the estimate: 85%; the middle value lies beyond the limit too.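

Compound 2 and compound 4 both sit at a limit in this assay, not at a number, so no step between them can be read: the limit of > 32000 nM in this assay, at which 2 of the 4 values shown sit.

The compounds shown leave open how far past the limit each of the two lies, and whether methylamino in place of hydroxy raises the number on the core of compound 2 as it does on the core of compound 1.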